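Series notes: amine-side aryl change from compound 3 to compound 4

The compounds below may be only part of what the source reports. "The series", "measured", "known", "first", "only" and "open" are said of these compounds alone.

In a functional assay on PC-3 cells (Homo sapiens) for inhibition, read by MTT assay, with a stated time of 72 h (a lower number here means a stronger inhibitor, a higher number a weaker inhibitor), compound 1 `O=C(CSc1nc(Nc2ccccc2)c2ccccc2n1)Nc1ccccc1F` gives 12400 nM, compound 2 `O=C(CSc1nc(Nc2ccccc2)c2ccccc2n1)Nc1ccc([N+](=O)[O-])cc1` gives 25000 nM and compound 3 `C=CC(=O)Nc1cccc(NC(=O)CSc2nc(Nc3ccccc3C)c3ccccc3n2)c1` gives 23200 nM. Compound 3 thus holds the second highest of the three numbers, but both other values lie within the scatter of it. Going by the values given here, the only single-site step measured so far, a 2.0-fold higher number from compound 1 to compound 2 (0.30 log units; within the scatter), concerns the amide-type nitrogen and does not reach beyond the scatter. Compound 4 `C=CC(=O)Nc1cccc(NC(=O)CSc2nc(Nc3cccc(OC)c3)c3ccccc3n2)c1` differs from compound 3 by 3-methoxyphenyl in place of 2-methylphenyl on a nitrogen on an aromatic ring. Among the compounds with values here, no measured step touches this nitrogen, so the series offers no basis for a shift there. The expected step is therefore a 1.0-fold lower number from compound 3 to compound 4 (0.00 log units; within the scatter), none beyond the scatter. Compound 4 is estimated at 23000 nM in this assay, with a range of 8000 nM to 65000 nM.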

Compound 4, half-maximal inhibitory concentration: 34900 nM
The estimate for compound 4 lay 1.5-fold (0.18 log units) below the measured number; low and high end bracket the measured number.
By their numbers in this assay, from the lowest: compounds 1, 3, 2 and 4 (each within the scatter of the next, the first and the last beyond it).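

On the nitrogen on an aromatic ring, 3-methoxyphenyl in place of 2-methylphenyl gives a 1.5-fold higher number from compound 3 to compound 4 (0.18 log units; within the scatter) in this assay. This first measured step at the position therefore resolves no difference between the two aryl groups. No supporting data bear on this result. Still open, on these data alone, is whether an aryl group carrying a carboxylic acid or an amine on this nitrogen would give a step beyond the scatter. The compounds shown also do not separate the effect of methyl versus methoxy from that of ring placement, which 3-methylphenyl would address.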